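The compounds below may be only part of what the source reports. "The series", "measured", "known", "first", "only" and "open" are said of these compounds alone.

Working notes on the series. Going by the values given here, compound 3 `Cc1cc(OCC(C)C)cc(C)c1-c1cccc(COc2ccc(S(=O)(=O)CC(=O)O)cc2)c1` gives 95.5 nM in a functional assay on CHO cells for agonist activity at Free fatty acid receptor 1 (Homo sapiens), read by FLIPR and calcium flux (on this read-out lower numbers stand for an effect already at smaller amounts and higher numbers for an effect only at larger amounts of compound), the largest of the three numbers measured so far, though all three lie within the scatter of one another. Compound 1 `COc1cc(C)c(-c2cccc(COc3ccc(S(=O)(=O)CC(=O)O)cc3)c2)c(C)c1` gives 57.5 nM in this assay, and compound 2 `CCOc1cc(C)c(-c2cccc(COc3ccc(S(=O)(=O)CC(=O)O)cc3)c2)c(C)c1` gives 63.1 nM. The group on the saturated chain carbon bound to an oxygen on an aromatic ring has been varied in three steps: a 1.1-fold higher number from compound 1 to compound 2 (0.04 log units; within the scatter), a 1.7-fold higher number from compound 1 to compound 3 (0.22 log units; within the scatter) and a 1.5-fold higher number from compound 2 to compound 3 (0.18 log units; within the scatter). None of these left the scatter. Compound 4 `Cc1cc(OCC2CC2)cc(C)c1-c1cccc(COc2ccc(S(=O)(=O)CC(=O)O)cc2)c1` changes the same place once more: cyclopropyl in place of isopropyl on a saturated chain carbon bound to an oxygen on an aromatic ring. All three measured steps alter this position and bear on the change; each was within the scatter, and a step of similar size is therefore expected here, with no direction beyond the scatter. The expected step is a 1.1-fold lower number from compound 3 to compound 4 (0.03 log units; within the scatter). For compound 4 the estimate in this assay is 90 nM, with a range from 45 nM to 180 nM.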

Compound 4, half-maximal effective concentration in the Free fatty acid receptor 1 assay: 79.4 nM
Compound 4: the middle estimate sits 1.1-fold (0.05 log units) above what was measured, and the stated range covers the measured number.
By their numbers in the Free fatty acid receptor 1 assay, from the lowest: compounds 1, 2, 4 and 3 (each within the scatter of the next).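

In the Free fatty acid receptor 1 assay cyclopropyl joins the other groups at this place without leaving the scatter: a 1.2-fold lower number from compound 3 to compound 4 (0.08 log units; within the scatter), a 1.3-fold higher number from compound 2 to compound 4 (0.10 log units; within the scatter) and a 1.4-fold higher number from compound 1 to compound 4 (0.14 log units; within the scatter). So far, this read-out separates none of the four compounds. In a physicochemical assay for lipophilicity, using the shake flask method, in phosphate buffer, measured as octanol-water partition, with a stated time of 24 h, at pH 7.4, tested at 100 uM (a higher number here means a more lipophilic compound, a lower number a more polar compound), compound 3 gives 3.94 and compound 4 gives 3.46. The new finding lies in the physicochemical assay, where cyclopropyl in place of isopropyl on a saturated chain carbon bound to an oxygen on an aromatic ring separates the pair beyond the scatter, towards the more polar side, while the number at the receptor stays within it: the measured distribution coefficient of compound 3, 3.94, and of compound 4, 3.46, a number 0.48 log units lower (beyond the scatter)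

On these data alone, whether an amine, a hydroxyl group or a longer chain at this place would carry the number in the Free fatty acid receptor 1 assay beyond the scatter stays open. Also open, as far as these compounds go, is how far such groups would shift the distribution coefficient in the physicochemical assay.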